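Fluoro for methoxy on a weakly cytotoxic thiazole amide

This account rests on a few compounds, and the source may have more. Where it says the series, first, only, none or still open, it means among the compounds named here.

Compound 1, `O=C(NCc1ccccc1)c1csc(-c2c[nH]c3ccccc23)n1`, in a functional assay on MDA-MB-231 cells (Homo sapiens) for cytotoxicity, read by MTT assay, with a stated time of 48 h, in the absence of a further agent (on this read-out lower numbers stand for stronger inhibition and higher numbers for weaker inhibition), gives > 100000 nM, which is a limit of the assay and not a number.
Compound 2, `COc1ccc2[nH]cc(-c3nc(C(=O)Nc4cc(OC)c(OC)c(OC)c4)cs3)c2c1`, in this assay gives > 100000 nM, likewise a limit.
Compound 3, `COc1ccc(NC(=O)c2csc(-c3c[nH]c4ccc(F)cc34)n2)cc1`, in this assay gives 49400 nM.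

Compound 2 stands at the limit of > 100000 nM in this assay, at which 2 of the 3 values shown sit, so for compound 2 nothing beyond that limit is known. Compound 4, `COc1cc(NC(=O)c2csc(-c3c[nH]c4ccc(F)cc34)n2)cc(OC)c1OC`, differs from compound 2 in one place: fluoro in place of methoxy on an aromatic carbon. Among the compounds with values here, no measured pair of compounds differing in only one place is available, so the size of such a step has not been observed here. Compound 3 carries the same fluoro but a different anilide and returns a number rather than a limit, yet compound 3 and compound 2 differ in more than one place, so their values are only reported side by side. Compound 4 is therefore expected to remain close to where compound 2 stands, with a step from compound 2 to compound 4 of an at least 1.2-fold lower number from compound 2 to compound 4 (0.09 log units; that floor lies within the scatter), not clearly beyond the scatter. For compound 4 the estimated value is 80000 nM, within a range of 25000 nM to 250000 nM.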

Compound 4, half-maximal inhibitory concentration: > 100000 nM
Compound 4: only a limit was reported; the forecaster's own chance of this, stated with the estimate: 55%; middle value at least 1.2-fold (0.09 log units) away from the limit.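

In this assay compound 4 gives > 100000 nM, a limit of the assay and not a number. Compound 2 also stands at a limit, so no step can be read between compound 2 and compound 4. The compounds shown leave open whether fluoro in place of methoxy on an aromatic carbon changes the read-out at all.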